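Acyl change at the amide of compound 3

The source may report more compounds than this note shows. Statements on the series, on what has been measured and on what is new or still open speak of the compounds shown alone.

compound 1 `COc1ccc(CNc2cc(OC)c(OC)c(OC)c2)cc1C`: 56800 nM
compound 2 `COc1cc(NCc2cccc(O)c2)cc(OC)c1OC`: 57600 nM
compound 3 `COc1ccc(CN(C(=O)CCCCCl)c2cc(OC)c(OC)c(OC)c2)cc1O`: 540 nM

Values are from a functional assay on MGC-803 cells (Homo sapiens) for inhibition, read by MTT assay, with a stated time of 48 h; a lower number here means a stronger inhibitor, a higher number a weaker inhibitor. Compound 3 holds the lowest number of the three, and its gap to compound 1 and to compound 2 lies beyond the scatter, so it is the strongest inhibitor shown. Compound 1 and compound 2 sit close to each other. Compound 4 `COc1ccc(CN(C(=O)C(C)C)c2cc(OC)c(OC)c(OC)c2)cc1O` is not yet measured and differs from compound 3 in one place: isopropyl in place of 4-chlorobutyl on a carbonyl carbon. No step between measured compounds matches this change; the only contrast shown is the wide gap between compound 3 and the other two, which carry no acyl group at all. The expected step from compound 3 to compound 4 in this assay is a moderate rise, a 2.8-fold higher number from compound 3 to compound 4 (0.44 log units; beyond the scatter). Compound 4 is estimated at 1500 nM, within 400 nM to 6000 nM.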

Compound 4, half-maximal inhibitory concentration: 210 nM
The estimate for compound 4 lay 7.1-fold (0.85 log units) above the measured number; the measured number lies below the stated range.
By their numbers in this assay, from the lowest: compound 4; then compound 3; then compounds 1 and 2 (each within the scatter of the next).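

In this assay isopropyl in place of 4-chlorobutyl on a carbonyl carbon gives a 2.6-fold lower number from compound 3 to compound 4 (0.41 log units; beyond the scatter). The amide position therefore accepts a shorter, branched acyl group, and neither the chlorine nor the 4-chlorobutyl chain is needed for activity in this pair. Nothing measured here accounts for the step.

As far as these compounds go, the chain and the chlorine change together, so their separate contributions stay open. Also open, from the compounds shown here alone, is how an unsubstituted butyl, a cyclopropyl, or a chain ending in an amine or a carboxylic acid would behave on this carbonyl carbon.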